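A few compounds are considered here, and "the series" means these few. Any claim that something is new, unique, unknown or untested is made for them only; others in the source may bear on it.

Compound 1 `COc1ccc(-c2noc(CCCCCCC(=O)NO)n2)cc1`; compound 2 `O=C(CCCCCCc1nc(-c2ccc(C(F)(F)F)cc2)no1)NO`; compound 3 `O=C(CCCCCCc1nc(-c2ccc(F)cc2)no1)NO`.

In an assay on isolated protein for inhibition of histone deacetylase 8 (Homo sapiens), read by fluorescence, with a stated time of 10 min (a higher number here means a weaker inhibitor, a lower number a stronger inhibitor), compound 1 gives only a limit, > 10000 nM. In this assay compound 2 likewise gives only a limit, > 10000 nM. In this assay compound 3 gives 8760 nM. Compound 3 thus stands as the only number shown, the other two values sitting at the limit of > 10000 nM in this assay, at which 2 of the 3 values shown sit. Compound 4 `O=C(CCCCCCc1nc(-c2cccnc2)no1)NO` differs from compound 3 by pyridin-3-yl in place of 4-fluorophenyl on an aromatic carbon. For the measured compounds named here, no measured step brings in a ring nitrogen, so only the two steps ending at compound 3 bear on it: an at least 1.1-fold lower number from compound 1 to compound 3 (0.05 log units; that floor lies within the scatter) and an at least 1.1-fold lower number from compound 2 to compound 3 (0.05 log units; that floor lies within the scatter), both floors within the scatter, while a step that the two limits leave unreadable from compound 1 to compound 2. Changes at this position have so far moved little, and little movement is expected for compound 4, a 1.0-fold higher number from compound 3 to compound 4 (0.01 log units; within the scatter). Compound 4 is estimated at 9000 nM, between 3000 nM and 30000 nM.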

Compound 4, half-maximal inhibitory concentration: 1830 nM
The estimate for compound 4 lay 4.9-fold (0.69 log units) above the measured number; the whole stated range lies above it.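

For the compounds shown here, with a 4.8-fold lower number from compound 3 to compound 4 (0.68 log units; beyond the scatter), this assay gives the first readable step at this position, and it lies beyond the scatter, so the group on this ring carbon can change the number. The step replaces a carbon-only ring bearing fluorine with a ring holding one nitrogen, and these compounds cannot separate those two differences. Compound 1 and compound 2 still give only limits: the limit of > 10000 nM in this assay, at which 2 of the 4 values shown sit.

Open, going by these compounds, is whether plain phenyl, without the fluorine, or pyridin-4-yl would give a number close to that of compound 4.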